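Sulfonyl in Place of a Chlorinated Phenyl at the Ring Nitrogen

The source may report more compounds than this note shows. Statements on the series, on what has been measured and on what is new or still open speak of the compounds shown alone.

Measured so far:
compound 1, `O=C(/C=C/c1ccccc1)c1ccc(N2CCN(c3cccc(Cl)c3Cl)CC2)cc1`: 30.7%
compound 2, `O=C(/C=C/c1ccc(Cl)cc1)c1ccc(N2CCN(c3cccc(Cl)c3)CC2)cc1`: 5.85%
compound 3, `O=C(/C=C/c1ccc(Cl)cc1)c1ccc(N2CCN(S(=O)(=O)c3ccc(C(F)(F)F)cc3)CC2)cc1`: 59.6%

Three compounds share a core in which one aromatic ring carries an unsaturated ketone on one side and a six-membered non-aromatic ring with two nitrogens on the other. In a functional assay on the whole organism (strain Kunming) for inhibition, with Mus musculus as the target, with a stated time of 1 h, at a dose of 40 mg/kg by the oral route (on this read-out higher numbers stand for more inhibition at the one dose given (going by the name of the read-out) and lower numbers for less inhibition), compound 1 gives 30.7%, the second highest of the three numbers. Compound 2 gives a number that is lower, at 5.85%, and compound 3 gives a number that is higher, at 59.6%; both of these gaps to compound 1 lie beyond the usual scatter of the measurement. Within the data shown here, compound 3 is the only measured compound that carries a sulfonyl-linked aromatic ring on the ring nitrogen; compounds 1 and 2 carry a chlorinated phenyl there, and compound 3 also differs from compound 1 in its other aromatic ring, so no single-change step between measured compounds exists.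

Compound 4, `O=C(/C=C/c1ccccc1)c1ccc(N2CCN(S(=O)(=O)c3ccc(Br)cc3)CC2)cc1`, has not yet been measured. It differs from compound 1 in one place: (4-bromophenyl)sulfonyl in place of 2,3-dichlorophenyl on an amine nitrogen in a ring. Because compound 3, which carries a related sulfonyl group, gives 59.6%, the expected step of a number 17.3 percentage points higher from compound 1 to compound 4 (beyond the scatter) is upward and beyond the scatter. Compound 4 is estimated at 48%, with a likely range from 25% to 70%.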

Compound 4, a percentage reported as inhibition, in the whole organism at one dose (the size of the read-out at that dose, not a potency): 47.4%
Beside the measured number, compound 4's estimate is 0.6 percentage points above it, within the range that was stated.
By their numbers in this assay, from the lowest: compound 2; then compound 1; then compound 4; then compound 3.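

Among these compounds, replacing 2,3-dichlorophenyl with (4-bromophenyl)sulfonyl on the amine nitrogen in the ring gives a number 16.7 percentage points higher from compound 1 to compound 4 (beyond the scatter) in this assay, the first reading of a change made at this position alone. Among the compounds shown here, the sulfonyl-linked aromatic ring was previously seen only in compound 3, which also differs from compound 1 in its other aromatic ring, whereas this step shows that a rise beyond the scatter can arise at the ring nitrogen with that other ring unchanged. Nothing shown here gives a measured property that accounts for the rise.

This single step changes several things at once: the sulfonyl link arrives with its hydrogen-bond acceptors, and bromine replaces the two chlorines, so the compounds shown cannot say which of these matters. A benzoyl group or a methylsulfonyl group on the same nitrogen, or a (4-chlorophenyl)sulfonyl group, would help separate the link, the aromatic ring and the halogen.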